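The compounds below may be only part of what the source reports. "The series", "measured", "known", "first", "only" and "open" are said of these compounds alone.

Compound 1 `CCSc1ccc(C2C(Oc3ccccc3)C(=O)N2c2cc(OC)c(OC)c(OC)c2)cc1` gives 632 nM in a functional assay on HT-29 cells (Homo sapiens) for inhibition, read by sulforhodamine B assay, with a stated time of 72 h; a lower number here means a stronger inhibitor, a higher number a weaker inhibitor
Compound 2 `CCSc1ccc(C2C(O)C(=O)N2c2cc(OC)c(OC)c(OC)c2)cc1` gives 12 nM
Compound 3 `C=CC1C(=O)N(c2cc(OC)c(OC)c(OC)c2)C1c1ccc(SC)cc1` gives 113 nM

Compound 3 holds the middle place of these three numbers, beyond the scatter from both others. Compound 4 `C=CC1C(=O)N(c2cc(OC)c(OC)c(OC)c2)C1c1ccc(SCC)cc1` differs from it by methyl in place of hydrogen on a saturated chain carbon bound to a sulfur and this turns methylsulfanyl to ethylsulfanyl. Among the measured compounds shown here, the only measured step is a 53-fold lower number from compound 1 to compound 2 (1.72 log units; beyond the scatter) but it lies elsewhere, with ethylsulfanyl on both compounds, so no measured pair tests this change. Compound 2 does show that an ethylsulfanyl compound can reach 12 nM in this assay so no step beyond the scatter is expected. The estimated step is a 1.1-fold higher number from compound 3 to compound 4 (0.03 log units; within the scatter) and it carries no real direction. For compound 4 the estimate is 120 nM with an expected range from 45 nM to 320 nM in this reading.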

Compound 4, half-maximal inhibitory concentration: 257 nM
Compound 4: middle estimate off by 2.1-fold (0.33 log units), on the low side; the measured number falls inside the stated range.
By their numbers in this assay, from the lowest: compound 2; then compound 3; then compound 4; then compound 1.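

In this assay the chain on the sulfur is not a silent position: methylsulfanyl to ethylsulfanyl weakens the vinyl compounds modestly (a 2.3-fold higher number from compound 3 to compound 4 (0.36 log units; beyond the scatter)). With ethylsulfanyl held fixed, the group on the saturated ring carbon counts for more, since vinyl in place of hydroxy costs far more (a 21-fold higher number from compound 2 to compound 4 (1.33 log units; beyond the scatter)). Vinyl in place of phenoxy instead improves the number (a 2.5-fold lower number from compound 1 to compound 4 (0.39 log units; beyond the scatter)).

Nothing shown gives a reason for these steps. Open, as far as these compounds go, are whether a longer chain such as propylsulfanyl continues this trend, and whether an amine on the ring carbon could match hydroxy.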